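The compounds below may be only part of what the source reports. "The series", "measured", "known", "first", "only" and "open" are said of these compounds alone.

Working notes on the series in a functional assay on the whole organism for agonist activity, with Mus musculus as the target; a lower number here means that less compound is needed, a higher number that more compound is needed for the effect.

Compound 1 `CCOC(=O)N(C)C(C)C#CCN1CCCC1` returns only a limit of the assay, > 100 mg/kg, not a number. Compound 2 `CCOC(=O)N(C)C(C)C#CCn1ccnc1` likewise returns only the limit > 100 mg/kg. The two differ by 1H-imidazol-1-yl in place of pyrrolidin-1-yl on a saturated chain carbon bound to a triple-bonded carbon, and the step that the two limits leave unreadable from compound 1 to compound 2 has no readable size, both partners being at the limit; the limit of > 100 mg/kg in this assay, at which 2 of the 3 values shown sit, covers two of the three values shown. Within the data shown here, compound 3 `CN(C)C(=O)N(C)CC#CCN1CCCC1` is the single compound with a number: in this assay compound 3 gives 1.2 mg/kg. How the core of compound 3 differs from the core of compound 1 is not broken down here.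

Compound 4 `CN(C)C(=O)N(C)CC#CCn1ccnc1` has not been measured in this assay. From compound 3 it differs by 1H-imidazol-1-yl in place of pyrrolidin-1-yl on a saturated chain carbon bound to a triple-bonded carbon, which is the same change as the one separating compound 1 and compound 2, occurring twice among the compounds shown, at the same place in both pairs. The earlier instance gives no size to carry over, so the expectation leans on the number for compound 3, 1.2 mg/kg, and on the fact that the same change on the core of compound 1 left both partners outside the readable range. The step expected in this assay is a 10-fold higher number from compound 3 to compound 4 (1.00 log units; beyond the scatter), taken as a weakening of the response. Compound 4 is therefore estimated at 12 mg/kg, within a range from 2.5 mg/kg to 100 mg/kg, with a real chance that only a limit is returned.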

Compound 4, dose for half-maximal effect: 11.8 mg/kg
Estimate against measurement, compound 4: 1.0-fold (0.01 log units) above, within the range that was stated.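

In this assay, 1H-imidazol-1-yl in place of pyrrolidin-1-yl on a saturated chain carbon bound to a triple-bonded carbon gives a 9.8-fold higher number from compound 3 to compound 4 (0.99 log units; beyond the scatter), so on the core of compound 3 the change has a readable size, a weakening of the response that still leaves a number rather than a limit. On the core of compound 1 the same change cannot be read, compound 1 and compound 2 both standing at a limit of the assay and neither giving a number: the limit of > 100 mg/kg in this assay, at which 2 of the 4 values shown sit. Among these compounds, the series therefore holds only one readable instance of this change, and the pair at the limit neither confirms nor contradicts that the size seen on the core of compound 3 carries over to the core of compound 1.

Compound 1 and compound 3 differ in more than one place, so the compounds shown do not separate which part of the core goes with the difference between a limit and a number. Also open, from the compounds shown here alone, is how other groups at the same place would read on either core, for example piperidin-1-yl or an open-chain dimethylamino group, and whether the step would keep its size on a third core.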